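Changing the aromatic group on the ring nitrogen of compound 3

This account rests on a few compounds, and the source may have more. Where it says the series, first, only, none or still open, it means among the compounds named here.

Of the compounds shown here, three built on one shared core have been tested in a functional assay on A549 cells (Homo sapiens) for inhibition, read by MTT assay, with a stated time of 72 h; a higher number here means a weaker inhibitor, a lower number a stronger inhibitor. Compound 1 `COc1ccc(N2CCN(C(=S)N/N=C3\C(=O)Nc4ccc(Cl)cc43)CC2)cc1` gives 7680 nM. Compound 2 `O=C1Nc2ccc(Cl)cc2/C1=N/NC(=S)N1CCN(c2ccc(Cl)cc2)CC1` gives 8180 nM, and compound 3 `O=C1Nc2ccc(Cl)cc2/C1=N/NC(=S)N1CCN(c2ccc(F)cc2F)CC1` gives 11400 nM. Compound 3 has the highest of the three numbers, but it does not stand apart from the others: a 1.5-fold higher number from compound 1 to compound 3 (0.17 log units; within the scatter), and a 1.4-fold higher number from compound 2 to compound 3 (0.14 log units; within the scatter). Between the other two, a 1.1-fold higher number from compound 1 to compound 2 (0.03 log units; within the scatter).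

Compound 4 `O=C1Nc2ccc(Cl)cc2/C1=N/NC(=S)N1CCN(c2ccccc2[N+](=O)[O-])CC1` differs from compound 3 in a single place: 2-nitrophenyl in place of 2,4-difluorophenyl on an amine nitrogen in a ring. All three measured steps bear on this change, since each one alters the aromatic group carried by that ring nitrogen, whether by swapping the whole group or by exchanging one substituent on it. Every one of those steps stayed within the scatter. For the measured compounds named here, nothing among the measured compounds suggests that exchanging one aromatic group for another at this position moves the number in this assay by more than the scatter, in either direction. Compound 4 is therefore expected to give about 10000 nM, with a range from 4000 nM to 25000 nM. The expected step is a 1.1-fold lower number from compound 3 to compound 4 (0.06 log units; within the scatter).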

Compound 4, half-maximal inhibitory concentration: 5580 nM
For compound 4 the middle estimate is 1.8-fold (0.25 log units) above the measured one; the range from low to high includes it.
By their numbers in this assay, from the lowest: compounds 4, 1, 2 and 3 (each within the scatter of the next, the first and the last beyond it).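

With a 2.0-fold lower number from compound 3 to compound 4 (0.31 log units; beyond the scatter) in this assay this position gives its first step that passes the scatter, so exchanging one aromatic group for another on the ring nitrogen can move the number, though only modestly. That shift rests on a single pair, since compound 4 remains close to the other two compounds, with a 1.5-fold lower number from compound 2 to compound 4 (0.17 log units; within the scatter) and a 1.4-fold lower number from compound 1 to compound 4 (0.14 log units; within the scatter) both showing no separation that can be trusted. The four compounds therefore form a narrow series in which only the two at its ends can be told apart, and nothing shown accounts for the one step that stands out.

The compounds shown leave open whether the nitro group itself matters, as a plain phenyl on the ring nitrogen, or an aromatic ring bearing an amine or a carboxylic acid, would be needed to judge that. They also leave open whether the position tolerates something other than a substituted phenyl, such as a simple alkyl chain or a saturated ring, and whether that would move the number further than any aromatic exchange seen here.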